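A few compounds are considered here, and "the series" means these few. Any claim that something is new, unique, unknown or untested is made for them only; others in the source may bear on it.

In a functional assay on A2780 cells (Homo sapiens) for inhibition, read by sulforhodamine B assay (a higher number here means a weaker inhibitor of growth, a lower number a stronger inhibitor of growth), compound 3 `COc1ccc(-c2ccc(-c3ccc(-c4nc5c(O)cccc5[nH]4)cc3)cc2)cc1` gives 8640 nM. This places it between compound 1 `Cc1ccc2[nH]c(-c3ccc(-c4ccc(-c5ccc(N(C)C)cc5)cc4)cc3)nc2c1` at 2210 nM and compound 2 `CN(C)c1ccc(-c2ccc(-c3ccc(-c4nc5ccccc5[nH]4)cc3)cc2)cc1` at 100000 nM, with both gaps beyond the scatter.

Compound 4 `CN(C)c1ccc(-c2ccc(-c3ccc(-c4nc5c(O)cccc5[nH]4)cc3)cc2)cc1` keeps the core of compound 3 and has dimethylamino in place of methoxy on an aromatic carbon, para to a large group (dimethylamino in place of methoxy on an aromatic carbon). Among the compounds with values here, no measured step covers this exchange. Within the data shown here, the only step available, a 45-fold higher number from compound 1 to compound 2 (1.66 log units; beyond the scatter), is hydrogen in place of methyl on an aromatic carbon, with dimethylamino present in both compounds. It shows that a small change elsewhere in the molecule can produce a large shift when dimethylamino is present, but it does not give the effect of replacing methoxy. Its size widens the uncertainty without setting a direction, so no clear shift in this assay is expected. The expected step is a 1.4-fold lower number from compound 3 to compound 4 (0.16 log units; within the scatter), and a step beyond the scatter in either direction remains possible. For compound 4 the estimated value is 6000 nM, with an expected range from 1500 nM to 25000 nM.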

Compound 4, concentration for 50% growth inhibition: 3010 nM
Beside the measured number, compound 4's estimate is 2.0-fold (0.30 log units) above it; measured number inside the range.
By their numbers in this assay, from the lowest: compounds 1 and 4 (each within the scatter of the next); then compound 3; then compound 2.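

In this assay, the exchange of 4-methoxyphenyl to 4-(dimethylamino)phenyl now has a measured size at this position: a 2.9-fold lower number from compound 3 to compound 4 (0.46 log units; beyond the scatter), a modest step. With dimethylamino held constant, hydroxy in place of hydrogen on an aromatic carbon of the core accounts for a much larger step, a 33-fold lower number from compound 2 to compound 4 (1.52 log units; beyond the scatter), while the 4-hydroxy-1H-benzimidazol-2-yl and 5-methyl-1H-benzimidazol-2-yl ends are not separated, a 1.4-fold higher number from compound 1 to compound 4 (0.13 log units; within the scatter). Nothing at hand bears on what lies behind these steps.

From the compounds shown here alone, whether the step from methoxy to dimethylamino has the same size with the 5-methyl-1H-benzimidazol-2-yl end remains open. Also open, going by these compounds, is how a primary amine or morpholine would compare on that same aromatic carbon, and how a carboxylic acid would compare in place of the hydroxy.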